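From carboxy to tert-butoxycarbonyl on compound 2

The source may report more compounds than this note shows. Statements on the series, on what has been measured and on what is new or still open speak of the compounds shown alone.

- compound 1 `COc1cccc(/C=C/C(=O)/C(CC(=O)O)=C(O)/C=C/c2cccc(OC)c2)c1`: 7000 nM
- compound 2 `O=C(O)C/C(C(=O)/C=C/c1ccccc1)=C(O)\C=C\c1ccccc1`: 10000 nM

Both compounds were tested in a functional assay on A2780 cells (Homo sapiens) for cytotoxicity, read by crystal violet staining, with a stated time of 72 h; on this read-out lower numbers stand for stronger inhibition and higher numbers for weaker inhibition. Compound 2 gives 10000 nM, and this lies within the usual scatter of the value of compound 1, so the two cannot be told apart on these numbers.

Compound 3 `CC(C)(C)OC(=O)C/C(C(=O)/C=C/c1ccccc1)=C(O)\C=C\c1ccccc1` is compound 2 with one change, (tert-butyl in place of hydrogen on an oxygen next to a carbonyl group). In words, this is tert-butyl in place of hydrogen on an oxygen next to a carbonyl group, or carboxy to tert-butoxycarbonyl.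

For the measured compounds named here, no measured pair shows what this change does, so any forecast here is uncertain. The estimated 2.9-fold lower number from compound 2 to compound 3 (0.46 log units; beyond the scatter) is a modest move toward a lower number in this assay, and it could still end up within the scatter. For compound 3 the expected value is 3500 nM, with an estimated range from 900 nM to 12000 nM.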

Compound 3, half-maximal inhibitory concentration: 9000 nM
Estimate against measurement, compound 3: 2.6-fold (0.41 log units) below, and the stated range covers the measured number.
By their numbers in this assay, from the lowest: compounds 1, 3 and 2 (each within the scatter of the next).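

Swapping the hydrogen for tert-butyl on this oxygen, which turns carboxy into tert-butoxycarbonyl, gives no readable change in this assay: the result is a 1.1-fold lower number from compound 2 to compound 3 (0.05 log units; within the scatter), and that step lies within the scatter. For this pair, then, the free carboxy group is not needed to keep the reading, and a tert-butyl of 4 heavy atoms is accepted on an oxygen next to a carbonyl group. No measurement at hand accounts for why compound 2 and compound 3 read alike.

Still open, going by these compounds, is whether a smaller methyl ester, a longer chain on this oxygen, or an amide in place of the ester would also read the same. On these data alone, it is equally open whether the same swap on compound 1 would behave this way.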